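Adding Bromo to a Flat Series

The source may hold more compounds than are shown below. What is called first, only, known or untested is meant among the compounds shown, and "the series" means these compounds.

In a functional assay on HepG2 cells (Homo sapiens) for antiproliferative activity, read by fluorescence and resazurin assay, with a stated time of 48 h (on this read-out lower numbers stand for stronger inhibition and higher numbers for weaker inhibition), three compounds have been measured so far. Compound 1 `O=C(N/N=C/c1cccnc1)c1cc2ccc(O)cc2oc1=O` gives 18400 nM, compound 2 `O=C(N/N=C/c1cccnc1)c1cc2ccccc2oc1=O` gives 15900 nM, and compound 3 `CCOc1ccc2nc(Cl)c(/C=N/NC(=O)c3cc4cc(Br)ccc4oc3=O)cc2c1` gives 29000 nM. Compound 2 therefore lies within the scatter of both other compounds, and the three values set no clear order.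

The next compound, compound 4 `O=C(N/N=C/c1cccnc1)c1cc2cc(Br)ccc2oc1=O`, has bromo in place of hydrogen on an aromatic carbon of compound 2 (bromo in place of hydrogen on an aromatic carbon). Among the measured compounds shown here, no measured step makes this exact exchange. The closest evidence is a 1.2-fold lower number from compound 1 to compound 2 (0.06 log units; within the scatter), which replaces hydroxy with hydrogen and stays within the scatter. Bromo also occurs in compound 3, at 29000 nM, but that compound differs in other places too, and its value remains within the scatter of compound 2.

On this limited evidence, no shift beyond the scatter is expected in this assay, and the expected step is a 1.0-fold higher number from compound 2 to compound 4 (0.00 log units; within the scatter). Compound 4 is estimated at 16000 nM, with an expected range of 8000 nM to 32000 nM.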

Compound 4, half-maximal inhibitory concentration: 19000 nM
Compound 4: middle estimate off by 1.2-fold (0.07 log units), on the low side; the range from low to high includes it.
By their numbers in this assay, from the lowest: compounds 2, 1, 4 and 3 (each within the scatter of the next).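

In this assay, among the compounds shown here, placing bromo on an aromatic carbon of the shared core gives a 1.2-fold higher number from compound 2 to compound 4 (0.08 log units; within the scatter), the first direct reading of this exchange. The step shows that this position, para to a fused ring and meta to a fused ring, takes one bromine atom in place of hydrogen without a shift beyond the scatter, something the earlier step, which exchanged hydroxy for hydrogen, could not show. No measurement is available that would explain why the number holds within the scatter.

On these data alone, it remains open whether an amine, a carboxylic acid or a longer chain at this same position would move the number beyond the scatter. As far as these compounds go, it is also open whether bromo would give a similar step on the core of compound 1, which carries hydroxy.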